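From Bromo to Methyl on the Aromatic Carbon

The source may report more compounds than this note shows. Statements on the series, on what has been measured and on what is new or still open speak of the compounds shown alone.

For the measured compounds named here, in an assay for inhibition of kynurenine 3-monooxygenase (Rattus norvegicus), tested at 10 uM (on this read-out higher numbers stand for more inhibition at the one concentration tested (going by the name of the read-out) and lower numbers for less inhibition), compound 2 `COC(=O)C(=N)/C=C(\O)c1ccc(Br)cc1` gives 0%, the lowest of the two numbers measured so far. Its nearest neighbour is compound 1 `COC(=O)C(=N)/C=C(\O)c1ccc(Cl)cc1`, which in this assay gives 13%; between them the data show a number 13 percentage points lower from compound 1 to compound 2 (beyond the scatter). The move to compound 3 `COC(=O)C(=N)/C=C(\O)c1ccc(C)cc1` is methyl in place of bromo on an aromatic carbon. Going by the values given here, only that one measured step bears on this change, and it concerns a different substituent at the same aromatic carbon, so it offers no more than a loose guide of modest size. Compound 2 already sits at the floor of this assay, so a fall beyond the scatter cannot appear; a small rise is the most that seems plausible. The expected step is a number 5 percentage points higher from compound 2 to compound 3 (within the scatter). Compound 3 is therefore estimated to give 5% in this assay, with a range from 0% to 20%.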

Compound 3, a percentage reported as inhibition, at one concentration (the size of the read-out at that concentration, not a potency): 4%
The estimate for compound 3 lay 1 percentage points above the measured number, and the stated range covers the measured number.
By their numbers in this assay, from the lowest: compounds 2, 3 and 1 (each within the scatter of the next, the first and the last beyond it).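

In this assay the swap of bromo for methyl on this aromatic carbon gives a number 4 percentage points higher from compound 2 to compound 3 (within the scatter) and the swap of chloro for methyl gives a number 9 percentage points lower from compound 1 to compound 3 (within the scatter) in the same read-out. Compound 3 thus cannot be separated from either halogen compound, even though compound 1 and compound 2 stand beyond the scatter of each other, so methyl does not set itself apart from chloro or bromo at this place. Nothing measured here accounts for where these numbers fall.

From the compounds shown here alone, it remains open whether an amine, a carboxylic acid or a longer chain such as butyl at this aromatic carbon would give a number clear of these three compounds. Going by these compounds, it is also open whether the same substituents would behave alike at another carbon of the ring.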